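The source may report more compounds than this note shows. Statements on the series, on what has been measured and on what is new or still open speak of the compounds shown alone.

Compound 1 `Cc1cccc(NC(=O)CS(=O)(=O)c2nccc(Oc3c(C)cc(C#N)cc3C)n2)c1` gives 25700 nM in an ADME assay on MT4 cells (Homo sapiens) for cytotoxicity, read by MTT assay, with a stated time of 4 days; on this read-out higher numbers stand for lower toxicity in this test and lower numbers for higher toxicity in this test.
Compound 2 `Cc1cc(C#N)cc(C)c1Oc1ccnc(S(=O)(=O)CC(=O)Nc2ccc(Cl)cc2)n1` gives 16600 nM in this assay.
Compound 3 `Cc1cc(C#N)cc(C)c1Oc1ccnc(S(=O)(=O)CC(=O)Nc2cccc([N+](=O)[O-])c2)n1` gives 23600 nM in this assay.

Among these three, compound 1 has the highest number, yet its nearest neighbour compound 3 and even its furthest neighbour compound 2 both lie within the usual scatter of repeated measurements, so no compound here can be called more or less toxic than another. Compound 4 `Cc1cc(C#N)cc(C)c1Oc1ccnc(S(=O)(=O)CC(=O)Nc2ccc([N+](=O)[O-])cc2)n1` has not yet been measured in this assay. It differs from compound 1 in one place: 4-nitrophenyl in place of 3-methylphenyl on an amide-type nitrogen. Going by the values given here, two measured steps bear on this exchange. The step of a 1.5-fold lower number from compound 1 to compound 2 (0.19 log units; within the scatter) and the step of a 1.1-fold lower number from compound 1 to compound 3 (0.04 log units; within the scatter) both replaced the group on the amide-type nitrogen, and both left the number within the scatter. Compound 3 already carries a nitrophenyl group on that nitrogen, as 3-nitrophenyl, and stands close to compound 1. For compound 4, with 4-nitrophenyl in that position, no step beyond the scatter is therefore expected, and the expected move is a 1.2-fold lower number from compound 1 to compound 4 (0.07 log units; within the scatter). The estimate for compound 4 in this assay is 22000 nM, with a range from 10000 nM to 45000 nM.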

Compound 4, half-maximal cytotoxic concentration: 59600 nM
Beside the measured number, compound 4's estimate is 2.7-fold (0.43 log units) below it; measured number above the stated range.
By their numbers in this assay, from the lowest: compounds 2, 3 and 1 (each within the scatter of the next); then compound 4.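

Going by these compounds alone, the place of the nitro group on the ring carried by the amide-type nitrogen matters in this assay: going from 3-nitrophenyl to 4-nitrophenyl gives a 2.5-fold higher number from compound 3 to compound 4 (0.40 log units; beyond the scatter) and is one of the first steps in this set to lie beyond the scatter. The group on the ring matters as well, since nitro in place of chloro gives a 3.6-fold higher number from compound 2 to compound 4 (0.56 log units; beyond the scatter) and 4-nitrophenyl in place of 3-methylphenyl gives a 2.3-fold higher number from compound 1 to compound 4 (0.37 log units; beyond the scatter) in the direction of lower toxicity in this test, while compounds 1, 2 and 3 remain within the scatter of one another. Only the combination in compound 4 stands apart here, and nothing measured alongside these numbers offers a reason for that.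

The compounds shown leave open whether this rise belongs to the nitro group alone, or whether an amine or a carboxylic acid in its place on the same ring would also move the number. They also leave open whether the same exchange would behave in this way on a core other than the one shared by these four compounds.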